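The compounds below may be only part of what the source reports. "The series", "measured", "known", "first", "only" and "open" are said of these compounds alone.

Measured compounds in a functional assay on K562 cells (Homo sapiens) for inhibition, read by sulforhodamine B assay, with a stated time of 48 h, tested at 10 uM; a lower number here means less inhibition, a higher number more inhibition at the concentration tested (going by the name of the read-out):
compound 1 `Brc1cn2ccnc2c(-c2ccc3ncn(C4CCCCC4)c3c2)n1` gives 18%
compound 2 `c1ccc(-c2cn3ccnc3c(-c3ccc4ncn(C5CCCCC5)c4c3)n2)cc1` gives 70.6%
compound 3 `c1ccc2c(-c3cn4ccnc4c(-c4ccc5ncn(C6CCCCC6)c5c4)n3)cccc2c1` gives 30.9%

Compound 3 holds the second highest of the three numbers. Against compound 1 the step is a number 12.9 percentage points higher from compound 1 to compound 3 (beyond the scatter), while against compound 2 it is a number 39.7 percentage points lower from compound 2 to compound 3 (beyond the scatter), so the gap upward to compound 2 is much the larger one. Between the other two compounds the step is a number 52.6 percentage points higher from compound 1 to compound 2 (beyond the scatter).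

Compound 4 is `c1cn2cc(-c3ccsc3)nc(-c3ccc4ncn(C5CCCCC5)c4c3)c2n1`. The change from compound 3 is thiophen-3-yl in place of naphthalen-1-yl on an aromatic carbon. For the measured compounds named here, only one measured step involves the group that leaves, a number 39.7 percentage points lower from compound 2 to compound 3 (beyond the scatter), where naphthalen-1-yl entered in place of phenyl and the number fell by a large amount. Going by the values given here, the group entering now is not phenyl, and no compound carrying thiophen-3-yl has been measured, so the direction is taken from that step read backwards: a rise is expected, probably not the full return to the level of compound 2, with wide uncertainty either side. The estimate for compound 4 is 55%, between 30% and 78%. For compound 4 this means an expected step of a number 24.1 percentage points higher from compound 3 to compound 4 (beyond the scatter) in this assay.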

Compound 4, a percentage reported as inhibition, at one concentration (the size of the read-out at that concentration, not a potency): 22%
Beside the measured number, compound 4's estimate is 33 percentage points above it; measured number outside the range, below it.
By their numbers in this assay, from the lowest: compounds 1, 4 and 3 (each within the scatter of the next, the first and the last beyond it); then compound 2.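

In this assay, for the compounds shown here, thiophen-3-yl in place of phenyl gives a number 48.6 percentage points lower from compound 2 to compound 4 (beyond the scatter), so the high number of compound 2 does not carry over to this five-membered aromatic ring with 1 hetero atom, although the earlier compounds left a rise possible once naphthalen-1-yl, with its 10 heavy atoms, was removed. Thiophen-3-yl, with 5 heavy atoms, instead gives a number 8.9 percentage points lower from compound 3 to compound 4 (within the scatter) in place of naphthalen-1-yl and a number 4 percentage points higher from compound 1 to compound 4 (within the scatter) in place of bromo, which leaves compound 2 as the only one of the four beyond the scatter of all the others at this position. Phenyl therefore stands alone among the aromatic groups shown here, with one replacement larger and one smaller by heavy-atom count both giving far lower numbers, and nothing available bears on why this is so.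

Going by these compounds, whether the high number is specific to unsubstituted phenyl remains open, and a methoxy-substituted phenyl, a pyridinyl ring or a morpholine at this position would test that. On these data alone, the cyclohexyl group is also the same throughout, so the effect of replacing it with an isopropyl or a piperidine on this pattern is unknown.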